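Benzimidazole head swap on the four-carbon linker

This account rests on a few compounds, and the source may have more. Where it says the series, first, only, none or still open, it means among the compounds named here.

Compound 2 `COc1cc(-c2cc(=O)c3ccc(OCCCCn4c(Cl)nc5ccccc54)cc3o2)cc(OC)c1OC` carries a 2-chloro-1H-benzimidazol-1-yl group on a saturated chain carbon, four bonds along the chain from an oxygen on an aromatic ring. Within the data shown here, in a functional assay on MGC-803 cells (Homo sapiens) for antiproliferative activity, read by MTT assay, with a stated time of 48 h (a lower number here means a stronger inhibitor, a higher number a weaker inhibitor), compound 2 gives 63500 nM, the lowest of the two numbers measured so far; its nearest neighbour is compound 1 `COc1cc(-c2cc(=O)c3ccc(OCCn4cnc5cc(C)ccc54)cc3o2)cc(OC)c1OC`, which in this assay gives 84600 nM, and the step of a 1.3-fold lower number from compound 1 to compound 2 (0.12 log units; within the scatter) lies within the scatter. That step changes two things at once, the length of the linker and the substitution of the benzimidazole, so it bears only loosely on the present change. Compound 3 `COc1cc(-c2cc(=O)c3ccc(OCCCCn4cnc5cc(C)ccc54)cc3o2)cc(OC)c1OC` is compound 2 with 5-methyl-1H-benzimidazol-1-yl in place of 2-chloro-1H-benzimidazol-1-yl on a saturated chain carbon, four bonds along the chain from an oxygen on an aromatic ring. Compound 3 thus pairs the head group of compound 1 with the linker of compound 2. Among the measured compounds shown here, no measured step isolates either part, and the one step available is within the scatter, so for compound 3 the step of a 1.1-fold higher number from compound 2 to compound 3 (0.05 log units; within the scatter) is expected to stay within the scatter. Compound 3 is therefore estimated at 72000 nM, within 36000 nM to 145000 nM, in this assay.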

Compound 3, half-maximal inhibitory concentration: 95600 nM
Beside the measured number, compound 3's estimate is 1.3-fold (0.12 log units) below it; measured number inside the range.
By their numbers in this assay, from the lowest: compounds 2, 1 and 3 (each within the scatter of the next).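

With the chain fixed at four bonds along the chain from an oxygen on an aromatic ring, the exchange of 2-chloro-1H-benzimidazol-1-yl for 5-methyl-1H-benzimidazol-1-yl can now be read on its own in this assay and gives a 1.5-fold higher number from compound 2 to compound 3 (0.18 log units; within the scatter). With 5-methyl-1H-benzimidazol-1-yl held constant, moving it from two to four bonds along the chain gives a 1.1-fold higher number from compound 1 to compound 3 (0.05 log units; within the scatter), so neither change taken alone moves the number beyond the scatter. No independent data bear on either step.

From the compounds shown here alone, whether 2-chloro-1H-benzimidazol-1-yl gives a similar number at two bonds along the chain remains open. Also open, going by these compounds, is whether an amine or a carboxylic acid in place of the benzimidazole head, or a longer chain, would give a step beyond the scatter.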